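This account rests on a few compounds, and the source may have more. Where it says the series, first, only, none or still open, it means among the compounds named here.

Compound 1 `C#CCOC(=O)/C=C(C)/C=C/CC(C)CCCC(C)(C)OC` gives 4.66 in a physicochemical assay for lipophilicity; a lower number here means a more polar compound, a higher number a more lipophilic compound. Compound 2 `C=CCOC(=O)/C=C(C)/C=C/CC(C)CCCC(C)(C)OC` gives 5.53 in this assay, so the change vinyl in place of ethynyl on a saturated chain carbon bound to an oxygen next to a carbonyl group moved the number a number 0.87 log units higher from compound 1 to compound 2 (beyond the scatter). Compound 3 `C#CCSC(=O)/C=C(C)/C=C/CC(C)CCCC(C)(C)OC` gives 5.9 in this assay; the steps of a number 1.24 log units higher from compound 1 to compound 3 (beyond the scatter) and a number 0.37 log units higher from compound 2 to compound 3 (beyond the scatter) both lie beyond the scatter, and compound 3 stands highest of the three. The core of compound 3 differs from that of compound 1 by propargylsulfanyl in place of propargyloxy on a carbonyl carbon. Compound 4 `C=CCSC(=O)/C=C(C)/C=C/CC(C)CCCC(C)(C)OC` is not yet measured; it carries vinyl in place of ethynyl on a saturated chain carbon bound to a sulfur, the same kind of change as that between compound 1 and compound 2, though the place differs: there on a saturated chain carbon bound to an oxygen next to a carbonyl group, here on a saturated chain carbon bound to a sulfur. A step of a number 0.80 log units higher from compound 3 to compound 4 (beyond the scatter) is expected, resting on the step of a number 0.87 log units higher from compound 1 to compound 2 (beyond the scatter) made by the same change on the other core. Compound 4 is accordingly estimated at 6.7, between 6.3 and 7.2.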

Compound 4, partition coefficient: 6.77
For compound 4 the middle estimate is 0.07 log units below the measured one; low and high end bracket the measured number.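

In this assay, vinyl in place of ethynyl on a saturated chain carbon bound to a sulfur gives a number 0.87 log units higher from compound 3 to compound 4 (beyond the scatter), matching a number 0.87 log units higher from compound 1 to compound 2 (beyond the scatter) on the core of compound 1, while allylsulfanyl in place of allyloxy on a carbonyl carbon gives a number 1.24 log units higher from compound 2 to compound 4 (beyond the scatter), matching a number 1.24 log units higher from compound 1 to compound 3 (beyond the scatter), and the two changes together give a number 2.11 log units higher from compound 1 to compound 4 (beyond the scatter). The change therefore carries over at equal size between these two cores, but this rests on a single pair of cores and does not show that it would hold on any other core. No data bearing on the reason for this result are available.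

The compounds shown leave open how a saturated propyl group or a longer chain would stand against propargyl and allyl in this assay. Also open, going by these compounds, is where an amine nitrogen in place of the oxygen or sulfur on the carbonyl carbon would fall.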